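Swapping a branched cap for a straight chain on the amine

The source may hold more compounds than are shown below. What is called first, only, known or untested is meant among the compounds shown, and "the series" means these compounds.

Measured so far:
compound 1 `CCn1c(NC(C)(C)C)nc2ccsc2c1=O` gives 1500 nM in an assay on cells for inhibition of high affinity 3',5'-cyclic-AMP phosphodiesterase 7A (Homo sapiens), read by scintillation counting and cAMP accumulation, with a stated time of 30 min; on this read-out higher numbers stand for weaker inhibition and lower numbers for stronger inhibition
compound 2 `CCn1c(NC(C)C)nc2c(C3CCN(C(=O)c4ccccc4)C3)csc2c1=O` gives 1.5 nM in this assay

Compound 1 has the highest number of the two; compound 2 sits far lower, beyond the scatter, but it also carries a further substituent on the shared core, so its value says little about the amine cap alone. Compound 3 `CCCNc1nc2ccsc2c(=O)n1CC` differs from compound 1 only by propyl in place of tert-butyl on a nitrogen on an aromatic ring. Going by the values given here, with no matching pair measured, the step from compound 1 to compound 3 in this assay is expected to be small, likely within the scatter. Compound 3 is therefore estimated at 1200 nM, with a range from 300 nM to 5000 nM, which corresponds to an expected step of a 1.3-fold lower number from compound 1 to compound 3 (0.10 log units; within the scatter).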

Compound 3, half-maximal inhibitory concentration in the high affinity 3',5'-cyclic-AMP phosphodiesterase 7A assay: 1400 nM
For compound 3 the middle estimate is 1.2-fold (0.07 log units) below the measured one; the measured number falls inside the stated range.
By their numbers in the high affinity 3',5'-cyclic-AMP phosphodiesterase 7A assay, from the lowest: compound 2; then compounds 3 and 1 (each within the scatter of the next).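

Putting propyl in place of tert-butyl on this nitrogen gives, in the high affinity 3',5'-cyclic-AMP phosphodiesterase 7A assay, a 1.1-fold lower number from compound 1 to compound 3 (0.03 log units; within the scatter), so on this read-out the two caps cannot be told apart. The same change does matter in a physicochemical assay for solubility, in phosphate buffer, at pH 6.8 (a higher number here means a more soluble compound, a lower number a less soluble compound), where compound 1 gives 3.7 ug/mL and compound 3 gives 69 ug/mL, so the compound with the straight chain is far more soluble: the measured solubility of compound 1, 3.7 ug/mL, and of compound 3, 69 ug/mL, a 19-fold higher number (1.27 log units; beyond the scatter).

Going by these compounds, only these two caps can be compared here, so how a cyclopropyl ring or a chain ending in a hydroxyl group would behave on either read-out remains open. Also open, on these data alone, is whether the swap behaves the same way on the more heavily substituted core of compound 2.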